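Gallamide thioethers against Toll-like receptor 2: a small series

A few compounds are considered here, and "the series" means these few. Any claim that something is new, unique, unknown or untested is made for them only; others in the source may bear on it.

Measured compounds:
compound 1, `C#CCSC[C@H](NC(=O)c1cc(O)c(O)c(O)c1)C(=O)OC`: 71500 nM
compound 2, `COC(=O)[C@H](CSCc1ccc(F)cc1)NC(=O)c1cc(O)c(O)c(O)c1`: 50200 nM
compound 3, `C#CCSC[C@H](NC(=O)c1cc(O)cc(O)c1)C(=O)OC`: 41800 nM

In an assay on RAW264.7 cells for antagonist activity at Toll-like receptor 2 (Mus musculus), read by Griess assay, with a stated time of 24 h (on this read-out higher numbers stand for weaker inhibition and lower numbers for stronger inhibition), compound 1 gives 71500 nM. Compound 2 differs from compound 1 by 4-fluorophenyl in place of ethynyl on a saturated chain carbon bound to a sulfur, and the step of a 1.4-fold lower number from compound 1 to compound 2 (0.15 log units; within the scatter) does not exceed the scatter of the measurement. Compound 3 differs from compound 1 in the core, namely (hydrogen in place of hydroxy on an aromatic carbon); here too the step of a 1.7-fold lower number from compound 1 to compound 3 (0.23 log units; within the scatter) stays within the scatter. Compound 2 and compound 3 are within the scatter of each other, so none of the three measured compounds can be said to be stronger or weaker than the others in this assay.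

Compound 4, `COC(=O)[C@H](CSCc1ccc(F)cc1)NC(=O)c1cc(O)cc(O)c1`, has not yet been measured. It is related to compound 3 by 4-fluorophenyl in place of ethynyl on a saturated chain carbon bound to a sulfur, the same change, at the same place, that leads from compound 1 to compound 2. That earlier step, a 1.4-fold lower number from compound 1 to compound 2 (0.15 log units; within the scatter), was within the scatter, and the cores of compound 3 and compound 4 share the difference from compound 1 given by hydrogen in place of hydroxy on an aromatic carbon. On this basis compound 4 is expected to follow the pattern and sit close to compound 3 in this assay, with an estimated step of a 1.3-fold lower number from compound 3 to compound 4 (0.12 log units; within the scatter). The number expected for compound 4 is 32000 nM, most likely between 15000 nM and 70000 nM.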

Compound 4, half-maximal inhibitory concentration: 38400 nM
Beside the measured number, compound 4's estimate is 1.2-fold (0.08 log units) below it; low and high end bracket the measured number.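

Carried onto the core of compound 3, the change of ethynyl to 4-fluorophenyl on a saturated chain carbon bound to a sulfur gives a 1.1-fold lower number from compound 3 to compound 4 (0.04 log units; within the scatter) in this assay, and it reads as it did on the core of compound 1: the same change on two cores in this assay, a 1.4-fold lower number (0.15 log units; within the scatter) from compound 1 to compound 2 and a 1.1-fold lower number (0.04 log units; within the scatter) from compound 3 to compound 4, 1.3-fold (0.12 log units) apart, within the scatter of two such steps

The other change, hydrogen in place of hydroxy on an aromatic carbon, gives a 1.3-fold lower number from compound 2 to compound 4 (0.12 log units; within the scatter), and it also agrees with its earlier step: the same change on two cores in this assay, a 1.7-fold lower number (0.23 log units; within the scatter) from compound 1 to compound 3 and a 1.3-fold lower number (0.12 log units; within the scatter) from compound 2 to compound 4, 1.3-fold (0.12 log units) apart, within the scatter of two such steps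

Within the data shown here, both changes therefore carry from one core to the other without a visible difference in these four compounds, but all the steps stay within the scatter, so this shows only that neither change moved the number measurably on either core, and it does not show that a step of real size would carry over in the same way.

From the compounds shown here alone, it remains open whether any change at these two places can move the number beyond the scatter, for instance an amine or a longer chain on the saturated chain carbon bound to a sulfur, or a carboxylic acid in place of the ester. Going by these compounds, all of these values also come from a single assay, so whether the agreement holds on any other read-out is unknown.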